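Notes on compounds 1 to 4 in the aortic assay

The compounds below may be only part of what the source reports. "The series", "measured", "known", "first", "only" and "open" are said of these compounds alone.

Measured so far:
- compound 1 `CC1(C)Oc2ccc(C#N)cc2[C@@H](/N=C(\NC#N)Nc2ccccc2)[C@@H]1O`: 1400000 nM
- compound 2 `CC1(C)CN(C(=O)Nc2cccnc2)c2cc(C#N)ccc21`: 1500000 nM
- compound 3 `CC(C)(C)c1ccc(C#N)cc1NC(=O)Nc1cccnc1`: 25700000 nM

In a functional assay (aorta) for inhibition, with Rattus norvegicus as the target (a higher number here means a weaker inhibitor, a lower number a stronger inhibitor), compound 3 gives 25700000 nM, the highest of the three numbers; compound 2 gives 1500000 nM and compound 1 gives 1400000 nM, both beyond the scatter away from compound 3, so compound 3 is the weakest inhibitor of the three. Compound 4 `CC(C)(C)c1ccc(C#N)cc1NC(=O)Nc1ccncc1` has not been measured in this assay. It differs from compound 3 in one place: pyridin-4-yl in place of pyridin-3-yl on an amide-type nitrogen. Among the compounds with values here, no measured pair shows this change, so its size is not known from the numbers here. With the same atoms joined differently and the rest of the structure kept, the expectation is for no step beyond the scatter in this assay, with some allowance in either direction. The expected step is a 1.0-fold lower number from compound 3 to compound 4 (0.01 log units; within the scatter). Compound 4 is estimated at 25000000 nM, with a range from 6000000 nM to 100000000 nM.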

Compound 4, half-maximal inhibitory concentration: 7800000 nM
The estimate for compound 4 lay 3.2-fold (0.51 log units) above the measured number; low and high end bracket the measured number.
By their numbers in this assay, from the lowest: compounds 1 and 2 (each within the scatter of the next); then compound 4; then compound 3.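

In this assay, pyridin-4-yl in place of pyridin-3-yl on an amide-type nitrogen gives a 3.3-fold lower number from compound 3 to compound 4 (0.52 log units; beyond the scatter) with the atoms unchanged and only their connection altered. Within the data shown here, this is the first single-place comparison, and it shows that the number at this position responds to where the nitrogen sits in the pyridine ring, even though the heavy-atom, donor and acceptor counts of the two groups are the same. No measurement at hand bears on the origin of this step.

Going by these compounds, whether the same exchange would give a step of similar size on the core of compound 2 remains open. Also open, on these data alone, is how pyridin-2-yl, a phenyl ring or a simple alkyl chain would stand on the same amide-type nitrogen.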